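Swapping 6-bromopyridin-3-yl for 4-hydroxyphenyl on the shared core

The source may report more compounds than this note shows. Statements on the series, on what has been measured and on what is new or still open speak of the compounds shown alone.

In an ADME assay on a cell-free system (plasma, Rattus norvegicus) for metabolic stability, read by LC-MS, with a stated time of 1 h, tested at 100 uM (a higher number here means that more of the compound is left, a lower number that less of the compound is left), compound 1 `CC1=C(c2nc(-c3ccc(C#N)cc3)cs2)C(c2cc3ccccc3n2C)NC(=O)N1` gives 95.6% and compound 2 `CC1=C(c2nc(-c3ccc(C#N)cc3)cs2)C(c2ccc(Br)nc2)NC(=O)N1` gives 98.3% which leaves compound 2 level with compound 1 within the scatter. Within the data shown here, compound 3 `CC1=C(c2nc(-c3ccc(C#N)cc3)cs2)C(c2ccc(O)cc2)NC(=O)N1` carries 4-hydroxyphenyl in place of 6-bromopyridin-3-yl on a saturated ring carbon and no measured compound holds that group. Among the measured compounds shown here, the one measured step that bears on this is a number 2.7 percentage points higher from compound 1 to compound 2 (within the scatter) with 6-bromopyridin-3-yl in place of 1-methyl-1H-indol-2-yl at that carbon. No step beyond the scatter is therefore expected in this assay for this change. The estimated step is a number 2.3 percentage points lower from compound 2 to compound 3 (within the scatter) and it is expected to stay small. Compound 3 is expected at 96% with an estimated range of 85% to 100% in this read-out.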

Compound 3, percent of the compound remaining: 100%
Beside the measured number, compound 3's estimate is 4 percentage points below it, within the range that was stated.
By their numbers in this assay, from the lowest: compounds 1, 2 and 3 (each within the scatter of the next).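

In this assay the change to 4-hydroxyphenyl gives a number 1.7 percentage points higher from compound 2 to compound 3 (within the scatter) and the change from 1-methyl-1H-indol-2-yl gives a number 4.4 percentage points higher from compound 1 to compound 3 (within the scatter) on the same saturated ring carbon. A carbon-only aromatic ring bearing a hydrogen-bond donor thus joins the two earlier groups at this position with no step beyond the scatter. No available evidence explains this result. The compounds shown leave open whether a carboxylic acid, an amine or a longer alkyl chain on that carbon would also stay within the scatter.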